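A Tert-Butyl Variant of a Methoxyethyl Agonist

The source may hold more compounds than are shown below. What is called first, only, known or untested is meant among the compounds shown, and "the series" means these compounds.

Compound 3 `CO[C@H](C)[C@H](N)CN(C(=O)[C@@H]1C[C@H]1c1ccccc1)c1ccc(-c2ccccc2)cc1` holds the lowest number among the compounds measured in a functional assay for agonist activity at G protein-coupled receptor 88 (Homo sapiens), read by HTRF and cAMP accumulation (on this read-out higher numbers stand for an effect only at larger amounts of compound and lower numbers for an effect already at smaller amounts), giving 0.68 nM. Its nearest neighbour is compound 2 `N[C@@H](CC1CCCCC1)CN(C(=O)[C@@H]1C[C@H]1c1ccccc1)c1ccc(-c2ccccc2)cc1`, which in this assay gives 1.7 nM; the step of a 2.5-fold lower number from compound 2 to compound 3 (0.40 log units; beyond the scatter) lies beyond the scatter. Compound 1 `CC[C@H](C)[C@H](N)CN(C(=O)[C@@H]1C[C@H]1c1ccccc1)c1ccc(-c2ccccc2)cc1` has two entries in this assay, 230 nM; 800 nM (2 entries), and both stand far above the other two compounds (the several entries of compound 1 in this assay, 230 nM; 800 nM (2 entries)).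

Compound 4 `CC(C)(C)[C@H](N)CN(C(=O)[C@@H]1C[C@H]1c1ccccc1)c1ccc(-c2ccccc2)cc1` differs from compound 3 in one place: tert-butyl in place of 1-methoxyethyl on a saturated chain carbon bound to an amine nitrogen and a saturated chain carbon. The entering group is a branched hydrocarbon without the hydrogen-bond acceptor of the leaving group, which brings compound 4 closer in kind to the branched alkyl of compound 1 and the cyclohexylmethyl of compound 2. Among the compounds with values here, only one measured step bears directly on this carbon, and it is modest in size; the two entries of compound 1 show that a small branched alkyl at this carbon can come with much higher numbers than compound 3 or compound 2. Compound 4 is therefore expected to return a higher number than compound 3, with the step of a 22-fold higher number from compound 3 to compound 4 (1.34 log units; beyond the scatter) taken as the estimate. In this assay compound 4 is expected to give about 15 nM, within a range from 2 nM to 120 nM.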

Compound 4, half-maximal effective concentration: 11 nM
Compound 4: the middle estimate sits 1.4-fold (0.13 log units) above what was measured; measured number inside the range.
By their numbers in this assay, from the lowest: compound 3; then compound 2; then compound 4.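

At the saturated chain carbon bound to an amine nitrogen and a saturated chain carbon, two groups equal in heavy atoms can sit far apart in this assay: exchanging 1-methoxyethyl, which holds an oxygen and a hydrogen-bond acceptor, for tert-butyl, which holds neither, gives a 16-fold higher number from compound 3 to compound 4 (1.21 log units; beyond the scatter). Hydrocarbon groups at this carbon also differ among themselves, since tert-butyl in place of cyclohexylmethyl gives a 6.5-fold higher number from compound 2 to compound 4 (0.81 log units; beyond the scatter), so the presence or absence of oxygen is not the only difference that goes with a change in the number here. Compound 4 also stands below both entries for the branched alkyl group of compound 1, which places the three hydrocarbon groups at clearly different levels: the several entries of compound 1 in this assay, 230 nM; 800 nM (2 entries)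

The compounds shown leave open whether the low number of compound 3 depends on the ether oxygen itself or on the shape of the group that carries it. A 1-hydroxyethyl or a methoxymethyl group at this carbon would bear on that question, and the opposite configuration at the methoxy-bearing carbon remains a further open point.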